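Moving a chlorine on an amide's phenyl ring

The source may hold more compounds than are shown below. What is called first, only, known or untested is meant among the compounds shown, and "the series" means these compounds.

compound 1 `O=C(O)CCCCC(CCSC(=O)c1ccccc1)SC(=O)c1ccccc1` gives 86.7%
compound 2 `O=C(CCCCC(CCSC(=O)c1ccccc1)SC(=O)c1ccccc1)Nc1ccccc1Cl` gives "not active" (no number reported)
compound 3 `O=C(CCCCC(CCSC(=O)c1ccccc1)SC(=O)c1ccccc1)Nc1cccc(Cl)c1` gives "not active" (no number reported)

These three compounds share one core and differ in what sits at its end. They were tested in a functional assay on HO8910 cells (Homo sapiens) for inhibition, read by MTT assay, with a stated time of 24 h, tested at 100 ug/mL (on this read-out lower numbers stand for less inhibition of growth and higher numbers for more inhibition of growth at the one concentration tested), and only compound 1 received a number. Compound 3 therefore has no exact place on the scale. It is reported only in words as "not active" (no number reported) and has no percentage to compare. The same is true of compound 2.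

The next compound to be measured is compound 4 `O=C(CCCCC(CCSC(=O)c1ccccc1)SC(=O)c1ccccc1)Nc1ccc(Cl)cc1` which has the same atoms as compound 3, joined differently (4-chlorophenyl in place of 3-chlorophenyl on an amide-type nitrogen). In words, 4-chlorophenyl stands in place of 3-chlorophenyl on an amide-type nitrogen, and nothing else changes.

The two closest relatives point the same way: compound 2 ("not active" (no number reported)) and compound 3 ("not active" (no number reported)) agree, and neither goes against the other. Two compounds are a thin basis, but the change is small. No step beyond the usual scatter is expected in this assay and the likeliest report is again one without a number. Should a number appear, compound 4 is estimated at 15% with an expected range from 0% to 45% on this scale.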

Compound 4, percent growth inhibition at one concentration: "not active" (no number reported)
Compound 4 has no reported number here, and the estimate cannot be compared.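

Compound 3 and compound 4 are both reported only in words as "not active" in this assay, so no step can be read between them. Nothing measured here bears on this result. The compounds shown leave open whether moving the chlorine has any effect on growth inhibition that a number could reveal.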